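A few compounds are considered here, and "the series" means these few. Any claim that something is new, unique, unknown or untested is made for them only; others in the source may bear on it.

Compound 1, `CCCOC(=O)CCC(=O)N1CCN(CCCOc2cc3c(Nc4ccc(F)c(Cl)c4)ncnc3cc2OC)CC1`: 95.1%
Compound 2, `CCCCOC(=O)CCC(=O)N1CCN(CCCOc2cc3c(Nc4ccc(F)c(Cl)c4)ncnc3cc2OC)CC1`: 94.4%
Compound 3, `CCCCCCOC(=O)CCC(=O)N1CCN(CCCOc2cc3c(Nc4ccc(F)c(Cl)c4)ncnc3cc2OC)CC1`: 89.3%

The three measured compounds share one core and differ only in the length of the ester chain. In a functional assay on A549 cells (Homo sapiens) for cytotoxicity, read by MTT assay, with a stated time of 24 h, tested at 10 uM (a higher number here means a weaker effect of the compound at the concentration tested, a lower number a stronger effect), compound 1 gives 95.1%, compound 2 gives 94.4%, and compound 3 gives 89.3%. Compound 3 has the lowest of the three numbers, but its steps from the other two, a number 5.8 percentage points lower from compound 1 to compound 3 (within the scatter) and a number 5.1 percentage points lower from compound 2 to compound 3 (within the scatter), are within the scatter, so no ordering among the three can be read from these values.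

Compound 4, `CCCCCCCCCCOC(=O)CCC(=O)N1CCN(CCCOc2cc3c(Nc4ccc(F)c(Cl)c4)ncnc3cc2OC)CC1`, differs from compound 3 in one place: butyl in place of hydrogen on a saturated chain carbon, six bonds along the chain from an oxygen next to a carbonyl group. The measured steps that bear on this change are the earlier chain extensions, a number 0.7 percentage points lower from compound 1 to compound 2 (within the scatter), a number 5.8 percentage points lower from compound 1 to compound 3 (within the scatter) and a number 5.1 percentage points lower from compound 2 to compound 3 (within the scatter), none of which reaches beyond the scatter. Each lengthening of the chain gave a slightly lower number, yet every one of these steps was small. For compound 4 a comparable small step is therefore expected in this assay, a number 4.3 percentage points lower from compound 3 to compound 4 (within the scatter), leaning lower but not clearly beyond the scatter. Compound 4 is estimated at 85% in this assay, with a range from 70% to 98%.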

Compound 4, a percentage reported as activity, at one concentration (the size of the read-out at that concentration, not a potency): 95.7%
For compound 4 the middle estimate is 10.7 percentage points below the measured one; the range from low to high includes it.
By their numbers in this assay, from the lowest: compounds 3, 2, 1 and 4 (each within the scatter of the next).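

In this assay, butyl in place of hydrogen on a saturated chain carbon, six bonds along the chain from an oxygen next to a carbonyl group, gives a number 6.4 percentage points higher from compound 3 to compound 4 (within the scatter), and compound 4 also stands within the scatter of the two other esters, with a number 1.3 percentage points higher from compound 2 to compound 4 (within the scatter) and a number 0.6 percentage points higher from compound 1 to compound 4 (within the scatter). The slight lean towards lower numbers seen across compound 1, compound 2 and compound 3 therefore does not carry on to compound 4, and across all four compounds no effect of ester chain length at this position stands clear of the scatter at the single concentration tested. No supporting measurement is available to explain these values.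

Within the data shown here, it remains open whether a longer chain than the one in compound 4, or an amine or a carboxylic acid in place of the ester chain, would give a number beyond the scatter. As far as these compounds go, it also remains open whether these four esters would separate from one another under conditions other than the single concentration and time used here.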